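The compounds below may be only part of what the source reports. "The series", "measured", "known", "first", "only" and "open" are said of these compounds alone.

Compounds measured so far:
compound 1, `Cc1cc(C)cc(CSc2nc(C3CCCCC3)c(C#N)c(=O)[nH]2)c1`, 7000 nM;
compound 2, `Cc1cc(C)c(CSc2nc(C3CCCCC3)c(C#N)c(=O)[nH]2)c(C)c1`, 11600 nM;
compound 3, `Cc1ccc(C)c(CSc2nc(C(C)C)c(C#N)c(=O)[nH]2)c1`, 12700 nM.

All three were tested in an assay on isolated protein for inhibition of Rap guanine nucleotide exchange factor 4 (Homo sapiens), read by fluorescence and cAMP accumulation; on this read-out higher numbers stand for weaker inhibition and lower numbers for stronger inhibition. For the measured compounds named here, compound 3 sits at the high end of the three numbers, but its gap to compound 2 and its gap to compound 1 both fall within the usual scatter, so no compound can be set apart from the others on these data. Compound 4, `Cc1ccc(C)c(CSc2nc(C3CCN(C)CC3)c(C#N)c(=O)[nH]2)c1`, has not been measured in this assay. It differs from compound 3 in one place: 1-methylpiperidin-4-yl in place of isopropyl on an aromatic carbon. Going by the values given here, no measured pair shows this change, so its size is unknown. The three measured compounds, with different groups at the same place, give numbers within the scatter of one another, so only a small step in this assay is expected, with no firm direction. Compound 4 is therefore estimated at 15000 nM, between 5000 nM and 45000 nM, a step of a 1.2-fold higher number from compound 3 to compound 4 (0.07 log units; within the scatter) expected in this assay.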

Compound 4, half-maximal inhibitory concentration: 127000 nM
Estimate against measurement, compound 4: 8.5-fold (0.93 log units) below; measured number above the stated range.
By their numbers in this assay, from the lowest: compounds 1, 2 and 3 (each within the scatter of the next); then compound 4.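

Putting 1-methylpiperidin-4-yl in place of isopropyl on the aromatic carbon ortho to a cyano group gives a step beyond the scatter in this assay (that is, a 10-fold higher number from compound 3 to compound 4 (1.00 log units; beyond the scatter)). The group at this position can therefore matter for inhibition, which the three earlier compounds could not show. Nothing measured here accounts for the step.

As far as these compounds go, whether it follows the ring nitrogen or simply the larger group stays open. Tetrahydropyran-4-yl, with oxygen in place of that nitrogen, on the core of compound 3 would bear on this.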